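The compounds below may be only part of what the source reports. "The series", "measured", "known", "first", "only" and "open" are said of these compounds alone.

Compound 1 `C=C(CC)C(=O)c1ccc(OCC(=O)NCCO)c(Cl)c1Cl` and compound 2 `C=C(CC)C(=O)c1ccc(OCC(=O)Nc2nc(/C(=N\OC)C(=O)O)cs2)c(Cl)c1Cl` share one core and were both tested in a functional assay on CLL cells (Homo sapiens) for cytotoxicity, read by MTT assay, with a stated time of 48 h; on this read-out higher numbers stand for an effect only at larger amounts of compound and lower numbers for an effect already at smaller amounts. In this assay compound 1 gives > 25000 nM, which is a limit of the assay and not a number. Compound 2 likewise gives > 25000 nM, again only a limit. For the measured compounds named here, both results sit at the limit of > 25000 nM in this assay, at which 2 of the 2 values shown sit, so no measured step is available. Compound 3 `C=C(CC)C(=O)c1ccc(OCC(=O)Nc2ccc(C#N)cc2)c(Cl)c1Cl` differs from compound 1 by 4-cyanophenyl in place of 2-hydroxyethyl on an amide-type nitrogen. The expected step from compound 1 to compound 3 is an at least 1.3-fold lower number from compound 1 to compound 3 (0.14 log units; that floor lies within the scatter), an estimate of a small gain at most, around the scatter. Compound 3 is therefore expected to give 18000 nM, between 4000 nM and 60000 nM.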

Compound 3, half-maximal effective concentration: 7800 nM
Compound 3: middle estimate off by 2.3-fold (0.36 log units), on the high side; the measured number falls inside the stated range.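

In this assay compound 3 gives a real number, 7800 nM, so the group on the amide-type nitrogen can move this read-out. The change gives an at least 3.2-fold lower number from compound 1 to compound 3 (0.50 log units; beyond the scatter). That size is only a floor, because compound 1 stands at a limit of the assay and not at a number: the limit of > 25000 nM in this assay, at which 2 of the 3 values shown sit.

The compounds shown leave open whether the nitrile or the aromatic ring carries this change, which a plain phenyl group would help to separate. They also leave open what a benzyl group would give there.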